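A few compounds are considered here, and "the series" means these few. Any claim that something is new, unique, unknown or untested is made for them only; others in the source may bear on it.

Series notes. Compound 1 `COc1ccccc1N1CCN(CC2(C)CCc3c(C)c(O)c(C)c(C)c3O2)CC1` and compound 2 `Cc1c(C)c2c(c(C)c1O)CCC(C)(CN1CCN(c3ncccn3)CC1)O2` share one core and differ only in the group carried on the amine nitrogen in a ring. In a functional assay (brain) for inhibition, with Rattus norvegicus as the target (a lower number here means a stronger inhibitor, a higher number a weaker inhibitor), compound 1 gives 1000 nM. In this assay compound 2 gives 1000 nM. Going by the values given here, the single step measured so far, no change at the digits printed from compound 1 to compound 2 (within the scatter), shows that swapping one six-membered aromatic group for another at this nitrogen left the read-out where it was. Compound 2 therefore stands level with compound 1 on the numbers in hand, and no order can be drawn between the two.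

Compound 3 `Cc1c(C)c2c(c(C)c1O)CCC(C)(CN1CCN(c3ccc(Cl)cc3)CC1)O2` is the next member. It differs from compound 2 as follows: 4-chlorophenyl in place of pyrimidin-2-yl on an amine nitrogen in a ring. Among the compounds with values here, the same position has already been varied once; that step, no change at the digits printed from compound 1 to compound 2 (within the scatter), was flat, and it is the only step that bears on the present change. Within the data shown here, no measured step speaks for a shift in either direction, so in this assay the expected step is one no larger than the scatter, no change at the digits printed from compound 2 to compound 3 (within the scatter). Compound 3 is accordingly estimated at 1000 nM, with a range from 300 nM to 3200 nM.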

Compound 3, half-maximal inhibitory concentration: 900 nM
The estimate for compound 3 lay 1.1-fold (0.05 log units) above the measured number, within the range that was stated.
By their numbers in this assay, from the lowest: compounds 3, 1 and 2 (each within the scatter of the next).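

In this assay the exchange of pyrimidin-2-yl, with 2 hydrogen-bond acceptors and a ring holding 2 hetero atoms, for 4-chlorophenyl, with 0 hydrogen-bond acceptors and a ring of carbon only, gives a 1.1-fold lower number from compound 2 to compound 3 (0.05 log units; within the scatter), so within this pair the read-out does not follow the acceptor count or the ring hetero atoms. The exchange of 2-methoxyphenyl for 4-chlorophenyl gives a 1.1-fold lower number from compound 1 to compound 3 (0.05 log units; within the scatter), which extends the flat result from a single pair to three six-membered aromatic groups on the same amine nitrogen in a ring, all within the scatter of one another. Nothing on hand explains this flat read-out.

The three compounds leave open whether the level of the series depends on an aromatic ring at this nitrogen at all, as a saturated cyclohexyl group, an acetyl group or a plain hydrogen on the nitrogen would test. They also leave open whether a charged group, such as a carboxylic acid on the phenyl ring, or a longer chain between the nitrogen and the aromatic ring, would move the number away from this shared level.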